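Mirror-image pair with one value at the limit

The compounds below may be only part of what the source reports. "The series", "measured", "known", "first", "only" and "open" are said of these compounds alone.

Measured in a functional assay on CCRF-CEM cells (Homo sapiens); on this read-out lower numbers stand for an effect already at smaller amounts and higher numbers for an effect only at larger amounts of compound:
- compound 1 (`Nc1ncn(C[C@H]2CO[C@H](CO)O2)c(=O)n1`) gives 30000 nM
- compound 2 (`Cc1nn(C[C@H]2CO[C@H](CO)O2)c(=O)[nH]c1=O`) gives > 100000 nM, which is a limit and not a number

Within the data shown here, compound 1 is the only compound here with a measured number, and that number is 30000 nM. Compound 2 sits at the limit of > 100000 nM in this assay, at which 1 of the 2 values shown sits. Its true value is therefore unknown, and it cannot be ranked precisely against compound 1.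

The next compound is compound 3 (`Cc1nn(C[C@@H]2CO[C@@H](CO)O2)c(=O)[nH]c1=O`). It has the same atoms and bonds as compound 2, and the change is purely one of configuration: the two compounds have the same atoms and bonds and differ only in configuration as drawn: 2 of 2 stereo elements differ (all stereocentres are inverted: mirror images); a stereocentre at a saturated ring carbon is drawn S in compound 2 and R in compound 3; a stereocentre at a saturated ring carbon is drawn S in compound 2 and R in compound 3. The two compounds are mirror images, so any difference between them in this assay would come from their handedness alone.

Among the measured compounds shown here, no mirror-image pair has been measured yet, so the data give no size for such a change. For the measured compounds named here, the only guide is compound 2 at > 100000 nM, and it points towards weak effect for compound 3 too. The expected change is a number no higher from compound 2 to compound 3 (the limit leaves the size open), which means no step beyond the usual scatter in either direction. For compound 3 the estimated value is 100000 nM, with an expected range from 40000 nM to 200000 nM.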

Compound 3, half-maximal effective concentration: > 100000 nM
Compound 3: only a limit was reported; the forecaster's own chance of this, stated with the estimate: 70%; the middle value sits exactly at the limit.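

In this assay compound 3 gives > 100000 nM, which is a limit and not a number. Compound 2 gives > 100000 nM, likewise a limit. No step can be read between these two mirror images. The compounds shown leave open whether handedness alters the effect at all in this assay, as the true values of both remain unknown.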